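This account rests on a few compounds, and the source may have more. Where it says the series, first, only, none or still open, it means among the compounds named here.

Measured so far:
compound 1 `CCCCOc1nc(C(F)(F)F)ccc1CNC(=O)Nc1cccc2c(=O)[nH]ccc12` — 160 nM
compound 2 `O=C(NCc1ccc(C(F)(F)F)nc1OCC1CCCC1)Nc1cccc2c(=O)[nH]ccc12` — 15.5 nM

Compound 2 stands at the lowest of the two numbers in an assay on CHO cells for agonist activity at transient receptor potential cation channel subfamily V member 1 (Homo sapiens); a lower number here means that less compound is needed, a higher number that more compound is needed for the effect; compound 1 is the nearest, and the step from it was a 10-fold lower number from compound 1 to compound 2 (1.01 log units; beyond the scatter). Among the measured compounds shown here, the single change from compound 2 to compound 3 `O=C(NCc1ccc(C(F)(F)F)nc1OCc1ccccc1)Nc1cccc2c(=O)[nH]ccc12` is phenyl in place of cyclopentyl on a saturated chain carbon bound to an oxygen on an aromatic ring. For the measured compounds named here, only one measured step bears on this place, the exchange of propyl for cyclopentyl, and it was large. Phenyl and cyclopentyl are both rings of comparable size at the same place, so the new change is smaller in kind than the one already seen, and no measured pair shows what an aromatic ring does here. Compound 3 is therefore expected to stay near compound 2, with an estimated step of a 1.6-fold higher number from compound 2 to compound 3 (0.21 log units; within the scatter) in this assay. The estimate for compound 3 is 25 nM, with a range from 6 nM to 100 nM.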

Compound 3, half-maximal effective concentration: 78.6 nM
For compound 3 the middle estimate is 3.1-fold (0.50 log units) below the measured one; measured number inside the range.
By their numbers in this assay, from the lowest: compound 2; then compound 3; then compound 1.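

In this assay, one ring cannot simply stand in for another at this place on the saturated chain carbon: replacing cyclopentyl with phenyl gives a 5.1-fold higher number from compound 2 to compound 3 (0.71 log units; beyond the scatter). Phenyl still compares well with the open chain, with a 2.0-fold lower number from compound 1 to compound 3 (0.31 log units; beyond the scatter), so both ring-bearing compounds need less compound than the propyl compound, and the kind of ring clearly matters too. Nothing available explains why the two rings differ.

Going by these compounds, what remains open is whether the gap between cyclopentyl and phenyl follows the aromatic ring or the ring size, and a cyclohexyl group at this place would help separate the two. It is also unknown how a pyridine ring, an amine or a longer chain on this carbon would compare with these three compounds.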